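The compounds below may be only part of what the source reports. "The series", "measured", "known", "first", "only" and "open" are said of these compounds alone.

Compound 1 `O=C(CSc1nc2cccnc2[nH]1)Nc1ccc(Cl)c(Cl)c1` and compound 2 `COc1ccc(NC(=O)CSc2nc3ccc(N(C)C)nc3[nH]2)cc1OC` were tested in an assay on isolated protein for inhibition of Ectonucleotide pyrophosphatase/phosphodiesterase family member 1 (Homo sapiens), tested at 10 uM; a lower number here means less inhibition, a higher number more inhibition at the concentration tested (going by the name of the read-out). In this assay compound 1 gives 10%, the lower of the two numbers, and compound 2 gives 58%, a result that stands beyond the scatter above it. Compound 3 `O=C(CSc1nc2cccnc2[nH]1)Nc1ccc(Cl)cc1` has not yet been measured. It differs from compound 1 in one place: hydrogen in place of chloro on an aromatic carbon. Compound 2 differs from compound 1 in several places at once, so its higher number does not tell what a single change does. For the measured compounds named here, no step between two measured compounds that differ in only one place is known, so the size of this change can only be expected. Because compound 1 already gives 10%, the expected step of a number 2 percentage points lower from compound 1 to compound 3 (within the scatter) is small, within the scatter, with no clear direction. Compound 3 is expected to give 8% in this assay, within -5% to 25%.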

Compound 3, a percentage reported as inhibition, at one concentration (the size of the read-out at that concentration, not a potency): 17%
Compound 3: middle estimate off by 9 percentage points, on the low side; the measured number falls inside the stated range.
By their numbers in this assay, from the lowest: compounds 1 and 3 (each within the scatter of the next); then compound 2.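

In this assay, replacing this chloro group with hydrogen gives a number 7 percentage points higher from compound 1 to compound 3 (within the scatter). For the compounds shown here, this is the first measured change in a single place, and it shows that this chloro group, on an aromatic carbon of a six-membered aromatic ring of carbon only and ortho to a chloro group, can give way to hydrogen with no change that stands out from the scatter of the measurement. Nothing measured here bears on why the step has this size.

On these data alone, it remains open whether a different group in this place, such as fluoro, nitrile or trifluoromethyl, would produce a step beyond the scatter. Going by these compounds alone, also open is which of the several differences in compound 2 goes with its higher number, as no single-place step connects it to compound 1 or compound 3.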